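A Trifluoromethyl Swap in a Series Held at Limits

The source may report more compounds than this note shows. Statements on the series, on what has been measured and on what is new or still open speak of the compounds shown alone.

In a functional assay on RXF 393 cells (Homo sapiens) for inhibition, read by sulforhodamine B assay, with a stated time of 48 h (on this read-out lower numbers stand for higher toxicity in this test and higher numbers for lower toxicity in this test), compound 3 (`O=C(Nc1cccc(-n2cc(-c3ccncc3)c(-c3ccc(Cl)c(O)c3)n2)c1)Nc1ccc(Cl)c(Cl)c1`) reads > 32500 nM, which is a limit and not a number. Compound 1 (`O=C(Nc1cccc(-n2cc(-c3ccncc3)c(-c3ccc(Cl)c(O)c3)n2)c1)Nc1cccc(C(F)(F)F)c1`) also gives a limit, > 32500 nM. Compound 2 (`COc1cc(-c2nn(-c3cccc(NC(=O)Nc4ccc(Cl)c(Cl)c4)c3)cc2-c2ccncc2)ccc1Cl`) gives another limit, > 50000 nM. Compound 4 (`O=C(Nc1cccc(-n2cc(-c3ccncc3)c(-c3ccc(Cl)c(O)c3)n2)c1)Nc1ccc(Cl)c(C(F)(F)F)c1`) carries trifluoromethyl in place of chloro on an aromatic carbon, ortho to a chloro group: trifluoromethyl in place of chloro on an aromatic carbon. Among the compounds with values here, two measured steps bear on this change, a step that the two limits leave unreadable from compound 1 to compound 3 and a step that the two limits leave unreadable from compound 2 to compound 3, and neither has a readable size. No shift beyond the usual scatter is therefore expected in this assay, in either direction. The estimated change is a step that the limit leaves unreadable from compound 3 to compound 4. For compound 4 the expected value is 38000 nM, with an estimated range from 15000 nM to 70000 nM.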

Compound 4, concentration lethal to 50% of the cells: > 32500 nM
Compound 4: a limit, no number; the forecaster's own chance of this, stated with the estimate: 75%; the middle value lies beyond the limit too.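

Within the data shown here, compound 4 gives only a limit, as do compound 1 and compound 3, so no step to compound 4 from either can be read. The compounds shown leave open what size, if any, these changes have in this assay.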